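The source may hold more compounds than are shown below. What is called first, only, known or untested is meant among the compounds shown, and "the series" means these compounds.

Measured in an ADME assay on HepG2 cells (Homo sapiens) for cytotoxicity; on this read-out higher numbers stand for lower toxicity in this test and lower numbers for higher toxicity in this test:
compound 1 `CSc1cccc(N2C(=O)CN(c3cccc(C(F)(F)F)c3)CC2C(=O)NC2CCCC2)c1` gives 20000 nM
compound 2 `CSc1cncc(N2C(=O)CN(c3cccc(C(F)(F)F)c3)CC2C(=O)NC2CCCC2)c1` gives 26000 nM
compound 3 `O=C(NC1CCCC1)C1CN(c2cccc(C(F)(F)F)c2)CC(=O)N1c1cccc(OC(F)(F)F)c1` gives 8000 nM

Of these three, compound 3 has the lowest number, so it is the most toxic to these cells in this small set. The next compound to be tested, compound 4 `CC(F)(F)c1cccc(N2C(=O)CN(c3cccc(C(F)(F)F)c3)CC2C(=O)NC2CCCC2)c1`, keeps the shared core and changes one group: 1,1-difluoroethyl in place of trifluoromethoxy on an aromatic carbon, with 1,1-difluoroethyl in place of trifluoromethoxy on an aromatic carbon.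

Going by the values given here, no measured compound carries 1,1-difluoroethyl, so the guidance is indirect. The closest guide is a 2.5-fold lower number from compound 1 to compound 3 (0.40 log units; beyond the scatter), where only the group at this same place differs, and that step is modest. The other step into compound 3, a 3.3-fold lower number from compound 2 to compound 3 (0.51 log units; beyond the scatter), is similar in size, but the aromatic ring changes along with the group, so it says less. Changing the ring alone gave a 1.3-fold higher number from compound 1 to compound 2 (0.11 log units; within the scatter), which does not separate those two compounds.

A swap at this place has so far moved the number only modestly, and compound 3 lies at the low end of the set. A small move towards a higher number therefore seems the likeliest outcome. The expected size is a 1.4-fold higher number from compound 3 to compound 4 (0.14 log units; within the scatter), a step estimated to stay within the scatter. Compound 4 is expected at about 11000 nM, with an estimated range from 5000 nM to 24000 nM.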

Compound 4, half-maximal cytotoxic concentration: 9000 nM
Compound 4: middle estimate off by 1.2-fold (0.09 log units), on the high side; measured number inside the range.
By their numbers in this assay, from the lowest: compounds 3 and 4 (each within the scatter of the next); then compounds 1 and 2 (each within the scatter of the next).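

In this assay, the swap of trifluoromethoxy for 1,1-difluoroethyl on an aromatic carbon gives a 1.1-fold higher number from compound 3 to compound 4 (0.05 log units; within the scatter), so the two groups cannot be told apart here, even though the entering group has no oxygen and no hydrogen-bond acceptor. Compound 4 also parts from the two compounds carrying methylsulfanyl, with a 2.2-fold lower number from compound 1 to compound 4 (0.35 log units; beyond the scatter) as the cleaner comparison and a 2.9-fold lower number from compound 2 to compound 4 (0.46 log units; beyond the scatter) as a less direct one, as the aromatic ring changes there too; a second fluorine-bearing group at this place therefore also sits lower than methylsulfanyl on the carbon ring, as trifluoromethoxy did in a 2.5-fold lower number from compound 1 to compound 3 (0.40 log units; beyond the scatter). Nothing measured alongside these numbers accounts for why these groups read as they do.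

The compounds shown leave open how an amine, a carboxylic acid or a longer chain at this place would read in this assay, and so whether the lower numbers belong to fluorine-bearing groups in general or only to these two. They also leave open whether 1,1-difluoroethyl would behave in the same way on the aromatic ring that contains nitrogen, where only methylsulfanyl appears.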